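The source may hold more compounds than are shown below. What is called first, only, known or untested is meant among the compounds shown, and "the series" means these compounds.

Measured compounds:
- compound 1, `CC(=O)N1CCCn2nc(COc3cccc(F)c3)cc21`: 58%
- compound 2, `CC(=O)N1CCCn2nc(COc3cc(F)cc(C#N)c3)cc21`: 39%

In a functional assay on HEK293 cells for positive allosteric modulation of metabotropic glutamate receptor 5 (Homo sapiens), read by calcium flux (a higher number here means a larger maximal response, a lower number a smaller maximal response), compound 1 gives 58% and stands highest of the two numbers measured; compound 2 gives 39%. Going by the values given here, the only measured step is a number 19 percentage points lower from compound 1 to compound 2 (beyond the scatter), brought about by cyano in place of hydrogen on an aromatic carbon.

Compound 3, `CC(=O)N1CCCn2nc(COc3cccnc3)cc21`, differs from compound 1 by pyridin-3-yl in place of 3-fluorophenyl on an oxygen on a saturated carbon. Among the compounds with values here, no measured step exchanges the aromatic ring on the oxygen for another ring, so the expectation rests on the one step that does touch this ring: a number 19 percentage points lower from compound 1 to compound 2 (beyond the scatter) was modest, though beyond the scatter, and it points to this ring as a place where changes register in this assay only moderately. A step of similar or smaller size is therefore expected, its direction uncertain, with a slight lean downward. Compound 3 is estimated to give 50% (range 30% to 70%), a step of a number 8 percentage points lower from compound 1 to compound 3 (within the scatter) expected.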

Compound 3, largest response reached (reported as percent of maximum), in percent of the reference or control that the assay uses: < 15%
Compound 3 gave a limit, no number; the forecaster's own chance of this, stated with the estimate: 5%; middle value at least 35 percentage points from the limit.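

In this assay, pyridin-3-yl in place of 3-fluorophenyl on the oxygen gives a number at least 43 percentage points lower from compound 1 to compound 3 (beyond the scatter), a large step, whereas the cyano step gave a number 19 percentage points lower from compound 1 to compound 2 (beyond the scatter), a modest one. This ring therefore registers far more strongly when it is exchanged for another ring than the cyano step alone suggested, and a maximal response as high as that of compound 1 does not survive this exchange. The value of compound 3 is a limit of the assay and not a number: the limit of < 15% in this assay, at which 1 of the 3 values shown sits.

The exchange removes the fluorine and brings in a ring nitrogen at once, and the compounds shown do not separate these two changes. As far as these compounds go, how an unsubstituted phenyl or a pyridin-4-yl would stand on the same oxygen in this assay remains open.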